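The source may report more compounds than this note shows. Statements on the series, on what has been measured and on what is new or still open speak of the compounds shown alone.

Three compounds share a common core carrying a benzyl group, and differ only in the aromatic ring attached to the six-membered ring with two nitrogens. Compound 1 `Cc1ccc(-c2nc(N)c3cc(Cc4ccccc4)sc3n2)o1` carries a 5-methylfuran-2-yl group and in a functional assay on CHO-K1 cells for antagonist activity at adenosine receptor A1 (Homo sapiens), read by a beta-galactosidase reporter and cAMP accumulation, with stated times of 15 min and 6 h (on this read-out higher numbers stand for weaker inhibition and lower numbers for stronger inhibition), compound 1 gives 298 nM. Compound 2 `Nc1nc(-c2ccc(C3CC3)o2)nc2sc(Cc3ccccc3)cc12` carries a 5-cyclopropylfuran-2-yl group, and compound 2 gives 861 nM, so that a 2.9-fold higher number from compound 1 to compound 2 (0.46 log units; beyond the scatter). Compound 3 `Nc1nc(-c2cccc(F)c2)nc2sc(Cc3ccccc3)cc12` carries a 3-fluorophenyl group and gives 123 nM, the lowest number of the three and thus the strongest inhibition here; from compound 1 a 2.4-fold lower number from compound 1 to compound 3 (0.38 log units; beyond the scatter), and a 7.0-fold lower number from compound 2 to compound 3 (0.85 log units; beyond the scatter).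

Compound 4 `Nc1nc(-c2ccccn2)nc2sc(Cc3ccccc3)cc12` is the next step: pyridin-2-yl in place of 3-fluorophenyl on an aromatic carbon. For the measured compounds named here, both measured steps toward compound 3 show that swapping a five-membered furan for a six-membered carbon ring lowered the number, but no measured step involves a six-membered ring with a nitrogen in it, so the data give no direct guide. Since compound 3 gives 123 nM with a six-membered ring, a six-membered ring that keeps that shape and adds one acceptor is expected to land near it, most likely with a modest rise: compound 4 is expected to give 250 nM, within 70 nM to 900 nM, an expected step of a 2.0-fold higher number from compound 3 to compound 4 (0.31 log units; beyond the scatter).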

Compound 4, inhibition constant: 3710 nM
For compound 4 the middle estimate is 15-fold (1.17 log units) below the measured one; the whole stated range lies below it.
By their numbers in this assay, from the lowest: compound 3; then compound 1; then compound 2; then compound 4.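

Keeping a six-membered aromatic ring at this position, on the aromatic carbon between two ring nitrogen atoms, does not by itself preserve the low number: in this assay, pyridin-2-yl in place of 3-fluorophenyl gives a 30-fold higher number from compound 3 to compound 4 (1.48 log units; beyond the scatter), the largest step at this position so far. Compound 4 also ranks behind both furan compounds, with a 12-fold higher number from compound 1 to compound 4 (1.10 log units; beyond the scatter) and a 4.3-fold higher number from compound 2 to compound 4 (0.63 log units; beyond the scatter), so the earlier impression that six-membered rings beat furans rests on compound 3 alone, and compound 4 goes against it. Nothing measured here explains why the number rises so sharply with this change.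

This single step both removes a fluorine and places a nitrogen in the ring, so the compounds shown cannot separate the effect of losing the fluorine from that of gaining the ring nitrogen. A plain phenyl group would help to pull these two changes apart, and pyridin-3-yl would show whether the result depends on where the nitrogen sits in the ring.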